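The source may report more compounds than this note shows. Statements on the series, on what has been measured and on what is new or still open speak of the compounds shown alone.

In an in vivo ADME assay on the whole organism (strain BALB/c) for pharmacokinetics, with Mus musculus as the target, read by LC-MS, at a dose of 5 mg/kg by the oral route (a lower number here means slower removal, a higher number faster removal of the compound), compound 1 `CCCS(=O)(=O)c1cccc(C#Cc2cc(Cl)ccc2OCC(=O)O)c1` gives 5 mL/min/kg. Compound 2 `COCCNS(=O)(=O)c1ccc(C)c(C#Cc2cc(Cl)ccc2OCC(=O)O)c1` gives 33.3 mL/min/kg, the higher of the two numbers, and the gap between them lies beyond the usual scatter. Going by the values given here, these two compounds differ in more than one place, so they show no single structural step. Compound 3 `Cc1ccc(S(=O)(=O)N2CCOCC2)cc1C#Cc1cc(Cl)ccc1OCC(=O)O` departs from compound 2 at one place, morpholin-4-yl in place of (2-methoxyethyl)amino on a sulfonyl sulfur: morpholin-4-yl stands in place of (2-methoxyethyl)amino on a sulfonyl sulfur. Among the compounds with values here, no measured pair shows this exchange, so the expectation rests on little. The only other reference, compound 1 at 5 mL/min/kg, draws the estimate slightly downward. The expected change is a 1.5-fold lower number from compound 2 to compound 3 (0.18 log units; within the scatter), a modest drop in this assay that is not expected to go beyond the scatter. For compound 3 the estimated clearance is 22 mL/min/kg, with an expected range from 8 mL/min/kg to 55 mL/min/kg.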

Compound 3, clearance: 31.7 mL/min/kg
The estimate for compound 3 lay 1.4-fold (0.16 log units) below the measured number; low and high end bracket the measured number.
By their numbers in this assay, from the lowest: compound 1; then compounds 3 and 2 (each within the scatter of the next).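

In this assay, the exchange on the sulfonyl sulfur gives a 1.1-fold lower number from compound 2 to compound 3 (0.02 log units; within the scatter), the first single-place change available here, and it stays within the scatter. At this place, then, (2-methoxyethyl)amino, an open chain with a hydrogen-bond donor, and morpholin-4-yl, a six-membered non-aromatic ring with no such donor, read alike in clearance. Nothing measured here explains why the two groups read alike.

The compounds shown leave open whether a piperazine or a dimethylamino group on the same sulfonyl sulfur would also read alike. They also cannot tie the lower number of compound 1 to any single structural feature, as it differs from compound 2 and compound 3 in more than one place.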